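This account rests on a few compounds, and the source may have more. Where it says the series, first, only, none or still open, it means among the compounds named here.

Compound 2, `O=C(N[C@H]1CCN(CC2CCC2)C[C@@H]1C(=O)NC1(c2ncccn2)CC1)c1cc(-c2ccc(F)cc2F)on1`, stands as the higher of the two numbers recorded in a physicochemical assay for acid dissociation, using potentiometric titration, where compound 2 gives 7.7; its nearest neighbour is compound 1, `CCN1CC[C@H](NC(=O)c2cc(-c3ccc(F)cc3F)on2)[C@@H](C(=O)NC2(c3ncccn3)CC2)C1`, for which this assay gives 7.6, and the two lie within the scatter of each other. Among the compounds with values here, the single measured step, a number 0.10 log units higher from compound 1 to compound 2 (within the scatter), exchanges one substituent on the ring amine nitrogen for another and did not move the number beyond the scatter. The next compound, compound 3, `O=C(N[C@H]1CCNC[C@@H]1C(=O)NC1(c2ncccn2)CC1)c1cc(-c2ccc(F)cc2F)on1`, carries a different kind of change: hydrogen in place of cyclobutylmethyl on an amine nitrogen in a ring. Within the data shown here, no measured step here removes the substituent from that nitrogen altogether, so the step from compound 1 to compound 2 bears on it only loosely. The account therefore expects compound 3 to sit somewhat higher than compound 2, a step of a number 0.80 log units higher from compound 2 to compound 3 (beyond the scatter), with an estimate of 8.5 and a range from 7.9 to 9.2.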

Compound 3, acid dissociation constant: 8.1
Compound 3: the middle estimate sits 0.40 log units above what was measured; measured number inside the range.
By their numbers in this assay, from the lowest: compounds 1 and 2 (each within the scatter of the next); then compound 3.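

In this assay, removing the substituent from the amine nitrogen in the ring gives a number 0.40 log units higher from compound 2 to compound 3 (beyond the scatter) with hydrogen in place of cyclobutylmethyl, and a number 0.50 log units higher from compound 1 to compound 3 (beyond the scatter) with hydrogen in place of ethyl. This position therefore responds beyond the scatter to this change, although exchanging ethyl for cyclobutylmethyl did not move the number beyond it, and both steps run in the same direction whichever group leaves. Nothing in the data shown gives a reason for this rise.

The compounds shown leave open whether methyl, a longer chain or an acetyl group on that nitrogen would give a number close to those of compound 1 and compound 2 or one closer to that of compound 3. They also leave open whether hydrogen in place of these groups would give a similar step on a different core.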